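This account rests on a few compounds, and the source may have more. Where it says the series, first, only, none or still open, it means among the compounds named here.

Of the compounds shown here, three that share one core have been measured in a functional assay on HEK293 cells for agonist activity at G-protein coupled receptor 39 (Homo sapiens), read by scintillation proximity assay and inositol phosphate accumulation, with a stated time of 75 min, in the presence of a further agent that is not named here; on this read-out higher numbers stand for an effect only at larger amounts of compound and lower numbers for an effect already at smaller amounts. Compound 1 `Cc1nn(-c2ncnc3nc[nH]c23)c2c1C(C(=O)Nc1ccccc1)CC(=O)N2` gives 10 nM. Compound 2 `Cc1cc(C)n(CCOC2CC(=O)Nc3c2c(C)nn3-c2ncnc3nc[nH]c23)n1` gives 16 nM. Compound 3 `Cc1nn(-c2ncnc3nc[nH]c23)c2c1C(C(=O)NCc1ccccc1)CC(=O)N2` gives 5 nM. Compound 2 thus gives the highest of the three numbers: the step of a 1.6-fold higher number from compound 1 to compound 2 (0.20 log units; within the scatter) lies within the scatter, whereas the step of a 3.2-fold lower number from compound 2 to compound 3 (0.51 log units; beyond the scatter) is beyond it, so only compound 3 stands clearly apart from compound 2.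

Compound 4 `COc1ccc(CCOC2CC(=O)Nc3c2c(C)nn3-c2ncnc3nc[nH]c23)cc1` has not yet been measured. It differs from compound 2 in one place: 4-methoxyphenyl in place of 3,5-dimethyl-1H-pyrazol-1-yl on a saturated chain carbon, two bonds along the chain from an oxygen on a saturated carbon. Going by the values given here, the two measured steps that exchange the group on a saturated ring carbon bear on this change, since each keeps the core and alters only that side group. The larger of them, a 3.2-fold lower number from compound 2 to compound 3 (0.51 log units; beyond the scatter), is modest, while a 1.6-fold higher number from compound 1 to compound 2 (0.20 log units; within the scatter) is within the scatter. A change of the present kind, which replaces only the aromatic part on a saturated chain carbon, is therefore expected to move this assay little, if at all, beyond the scatter, and if it moves, a somewhat lower number is the more likely direction. Compound 4 is estimated at 12 nM, with a range from 5 nM to 30 nM. That estimate means the step of a 1.3-fold lower number from compound 2 to compound 4 (0.12 log units; within the scatter) is expected.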

Compound 4, half-maximal effective concentration: 2 nM
Estimate against measurement, compound 4: 6.0-fold (0.78 log units) above, and the stated range ends above it.
By their numbers in this assay, from the lowest: compound 4; then compounds 3, 1 and 2 (each within the scatter of the next, the first and the last beyond it).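

In this assay there is an 8.0-fold lower number from compound 2 to compound 4 (0.90 log units; beyond the scatter) on exchanging 3,5-dimethyl-1H-pyrazol-1-yl for 4-methoxyphenyl, so the group at the end of this chain clearly affects the read-out. The earlier steps shown here exchanged the whole side group on the saturated ring carbon, whereas this one keeps the oxygen and the chain in place and alters only the end group, showing that this single change can outweigh those larger exchanges. No measurement shown here explains the step.

On these data alone, it remains open whether the methoxy group or the change from a five-membered aromatic ring with 2 hetero atoms to a six-membered ring of carbon only matters more, which an unsubstituted phenyl on this chain would help to separate. As far as these compounds go, it is also open how a longer chain, or an amine at the chain end, would read out.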